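Carboxy to carboxymethyl on two different cores

This account rests on a few compounds, and the source may have more. Where it says the series, first, only, none or still open, it means among the compounds named here.

Compound 1 `CC(C)Oc1ccc(-c2nnc(-n3cc4c(n3)CCN(CCC(=O)O)C4)s2)cc1Cl`: 3.26
Compound 2 `CC(C)Oc1ccc(-c2nnc(-n3cc4c(n3)CCN(CCCC(=O)O)C4)s2)cc1Cl`: 3.56
Compound 3 `Cc1nn(-c2nnc(-c3ccc(OC(C)C)c(Cl)c3)s2)c(C)c1CC(=O)O`: 3.62

Of the compounds shown here, three have been measured in a physicochemical assay for lipophilicity, at pH 7.4; a lower number here means a more polar compound, a higher number a more lipophilic compound. Compound 1 gives 3.26 in this assay, and compound 2 gives 3.56. The two differ by carboxymethyl in place of carboxy on a saturated chain carbon, two bonds along the chain from an amine nitrogen in a ring, a change that gives a number 0.30 log units higher from compound 1 to compound 2 (within the scatter). Compound 3 gives 3.62; how its core differs from that of compound 1 is not broken down here.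

Compound 4 `Cc1nn(-c2nnc(-c3ccc(OC(C)C)c(Cl)c3)s2)c(C)c1CCC(=O)O` has not yet been measured. It differs from compound 3 by carboxymethyl in place of carboxy on a saturated chain carbon bound to an aromatic carbon. This is the same kind of change as that from compound 1 to compound 2, but the place differs: in the earlier pair the chain carbon sits two bonds along the chain from an amine nitrogen in a ring, whereas here it is bound to an aromatic carbon. Because the earlier pair showed a number 0.30 log units higher from compound 1 to compound 2 (within the scatter), a step of similar size is expected from compound 3 to compound 4, namely a number 0.28 log units higher from compound 3 to compound 4 (within the scatter). Compound 4 is therefore estimated to give 3.9 in this assay, with a likely range from 3.6 to 4.2.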

Compound 4, distribution coefficient: 4.3
Compound 4: middle estimate off by 0.40 log units, on the low side; measured number outside the range, above it.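

In this assay, the change from carboxy to carboxymethyl gives a number 0.68 log units higher from compound 3 to compound 4 (beyond the scatter) on the core of compound 3, against a number 0.30 log units higher from compound 1 to compound 2 (within the scatter) on the core of compound 1. A step read on one core therefore did not carry over at the same size to the other: one step lies beyond the scatter and the other within it. Among these compounds, with only one pair on each core, this does not show whether the size of the step depends on the core, on the place of the change, or on the scatter of the measurements, and no measurement given here bears on why the two steps differ.

The compounds shown leave open how a longer chain ending in a carboxylic acid would read on either core. They also leave open whether an amide or an amine at the chain end would follow the same step when carried between the two cores.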